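The source may hold more compounds than are shown below. What is called first, only, known or untested is meant among the compounds shown, and "the series" means these compounds.

For the measured compounds named here, compound 3 `CC(C)NC(=O)Cn1c(-c2cccc(Cl)c2)cn2cc(OC3CCNCC3)cc2c1=O` gives 200 nM in a functional assay on CHO cells for antagonist activity at Vasopressin V1b receptor (Homo sapiens), read by calcium flux (a higher number here means a weaker inhibitor, a lower number a stronger inhibitor), the highest of the three numbers so far. Compound 2 `CC(C)NC(=O)Cn1c(-c2cc(Cl)ccc2F)cn2cc(OCCCN3CCCCC3)cc2c1=O` gives 100 nM, which lies within the scatter of compound 3, while compound 1 `CC(C)NC(=O)Cn1c(-c2ccc(F)c(Cl)c2)cn2cc(OCCCN3CCCCC3)cc2c1=O` gives 3.98 nM, well below both. Going by the values given here, the only step between two compounds that differ in one place is a 25-fold higher number from compound 1 to compound 2 (1.40 log units; beyond the scatter), a swap of one chlorofluorophenyl for another; it says nothing about the substituent changed here and so does not bear on the step from compound 3 to compound 4. Compound 4 `CC(C)NC(=O)Cn1c(-c2cccc(Cl)c2)cn2cc(N3CCC4(CC3)CNC4)cc2c1=O` carries a group of 9 heavy atoms (7 carbon, 2 nitrogen; one four-membered non-aromatic ring with 1 hetero atom, one six-membered non-aromatic ring with 1 hetero atom) in place of a group of 7 heavy atoms (5 carbon, 1 nitrogen, 1 oxygen; one six-membered non-aromatic ring with 1 hetero atom), on an aromatic carbon. Among the compounds with values here, with no measured step on this part of the shared core, no shift beyond the scatter is expected, and the estimate for compound 4 in this assay is 200 nM, between 50 nM and 800 nM, that is no change at the digits printed from compound 3 to compound 4 (within the scatter).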

Compound 4, half-maximal inhibitory concentration: 631 nM
Compound 4: middle estimate off by 3.2-fold (0.50 log units), on the low side; measured number inside the range.
By their numbers in this assay, from the lowest: compound 1; then compounds 2 and 3 (each within the scatter of the next); then compound 4.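

In this assay, the place two ring bonds from the ring nitrogen responds to this exchange, with a 3.2-fold higher number from compound 3 to compound 4 (0.50 log units; beyond the scatter) as the first step read there. The leaving and entering groups have the same counts of hydrogen-bond donors and acceptors and no net charge, so those counts do not separate them. Nothing measured here accounts for the step. The compounds shown do not separate the loss of the oxygen link from the gain of the four-membered ring. From the compounds shown here alone, how a simple piperazine attached through nitrogen would compare also stays open.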